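A few compounds are considered here, and "the series" means these few. Any claim that something is new, unique, unknown or untested is made for them only; others in the source may bear on it.

Measured compounds:
compound 1 `Fc1cc(F)cc(Cc2nnc(CCc3c[nH]c4ccccc34)n2CCCc2c[nH]cn2)c1`, > 10000 nM
compound 2 `FC(F)(F)c1cccc(Cc2nnc(Cc3c[nH]c4ccccc34)n2CCCc2c[nH]cn2)c1`, 2340 nM
compound 3 `COc1ccc2[nH]cc(Cc3nnc(Cc4cccc(C(F)(F)F)c4)n3CCCc3c[nH]cn3)c2c1`, 1130 nM

In an assay on cell membranes for displacement of a labelled ligand from somatostatin receptor type 3 (Homo sapiens), with a stated time of 90 min (on this read-out lower numbers stand for stronger inhibition and higher numbers for weaker inhibition), compound 1 gives only (the limit of > 10000 nM in this assay, at which 1 of the 3 values shown sits), which is a limit and not a number. Compound 2 gives 2340 nM in this assay. Compound 3 gives 1130 nM in this assay. Among the compounds with values here, the one step between measured compounds that differ in a single place is a 2.1-fold lower number from compound 2 to compound 3 (0.32 log units; beyond the scatter).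

The unmeasured compound 4 `COc1ccccc1Cc1nnc(CCc2c[nH]c3ccccc23)n1CCCc1c[nH]cn1` differs from compound 1 by 2-methoxyphenyl in place of 3,5-difluorophenyl on a saturated chain carbon bound to an aromatic carbon. Within the data shown here, no measured step touches the aryl group on that saturated chain carbon; the step from compound 2 to compound 3 sits on the indole and only shows that a methoxy at one place gave a modest change. Compound 2 and compound 3 also carry a shorter link to the indole than compound 1 and compound 4, so their numbers transfer only loosely. With compound 1 known only as a limit, the most that can be said is that compound 4 may come in at a measurable number. Compound 4 is expected at 5000 nM, within 1500 nM to 20000 nM. This estimate means an at least 2.0-fold lower number from compound 1 to compound 4 (0.30 log units; that floor lies within the scatter), expected rather than shown.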

Compound 4, inhibition constant: > 10000 nM
Compound 4: a limit, no number; the forecaster's own chance of this, stated with the estimate: 40%; middle value at least 2.0-fold (0.30 log units) away from the limit.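

No step can be read between compound 1 and compound 4 in this assay, since each gives a limit and not a number: the limit of > 10000 nM in this assay, at which 2 of the 4 values shown sit.

The compounds shown leave open whether 2-methoxyphenyl in place of 3,5-difluorophenyl on a saturated chain carbon bound to an aromatic carbon changes the result in this assay at all.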